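A few compounds are considered here, and "the series" means these few. Any claim that something is new, unique, unknown or untested is made for them only; others in the source may bear on it.

Compound 1, `N#CN/C(=N\CCNc1ccc(N=[N+]=[N-])cc1[N+](=O)[O-])NCCCOc1cccc(CN2CCCCC2)c1`: in a functional assay on cardiac atrium for antagonist activity at histamine H2 receptor (Cavia porcellus) (a lower number here means a less potent compound, a higher number a more potent compound, by a factor of ten per unit of this negative logarithm), compound 1 gives 7.39.
Compound 2, `N#CN/C(=N\CCCNC(=O)c1ccccc1)NCCCCOc1cccc(CN2CCCCC2)c1`: in this assay compound 2 gives 6.6.

Of the two measured compounds, compound 1 stands highest; compound 2 comes out lower by a gap that is beyond the usual scatter. Going by the values given here, compound 2 also carries an amide in place of the aryl amine of compound 1, but it differs from compound 1 in more than one place, so its value shows only that an amide-bearing analogue gave a lower number.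

Compound 3, `N#CN/C(=N\CCNC(=O)CCCc1ccccc1)NCCCOc1cccc(CN2CCCCC2)c1`, has not been measured. It differs from compound 1 in one place: (3-phenylpropyl)carbonyl in place of 4-azido-2-nitrophenyl on an amine nitrogen. Among the compounds with values here, with no one-place step of this kind among the measured compounds, the direction rests on the lower value of compound 2. A downward step is expected, short of what separates compound 1 and compound 2, giving a number 0.59 log units lower from compound 1 to compound 3 (beyond the scatter). Compound 3 is therefore estimated at 6.8, within a range from 6.2 to 7.4.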

Compound 3, negative logarithm of the antagonist equilibrium constant: 6.45
Estimate against measurement, compound 3: 0.35 log units above; the range from low to high includes it.
By their numbers in this assay, from the lowest: compounds 3 and 2 (each within the scatter of the next); then compound 1.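

In this assay, going by these compounds alone, this is the first one-place comparison at this amine nitrogen, and it gives a number 0.94 log units lower from compound 1 to compound 3 (beyond the scatter), with (3-phenylpropyl)carbonyl in place of 4-azido-2-nitrophenyl and the rest of the core unchanged. The number at this position therefore depends on the group attached there, even though both groups carry one six-membered aromatic ring of carbon only and differ little in heavy-atom count. Nothing measured here explains the drop.

Within the data shown here, the single step does not separate the loss of the azido and nitro groups from the entry of the carbonyl and its chain. The compounds shown leave open how a plain phenyl, a nitrophenyl or an azidophenyl group on this nitrogen would stand, and whether a benzoyl or acetyl group would give a different number from (3-phenylpropyl)carbonyl.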